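Removing a Methyl Group from Two Related Growth Inhibitors

The source may hold more compounds than are shown below. What is called first, only, known or untested is meant among the compounds shown, and "the series" means these compounds.

Measured in a functional assay on cells (Tumor Cell line, Homo sapiens) for antiproliferative activity; a higher number here means a weaker inhibitor of growth, a lower number a stronger inhibitor of growth:
compound 1 `Cc1ccnc2nc(-c3cccc(Cl)c3)cc(O)c12` gives 158 nM
compound 2 `Cc1cc(C)c2c(O)cc(-c3cccc4ccccc34)nc2n1` gives 1050 nM
compound 3 `Cc1cc(C)c2c(O)cc(-c3cccc(Cl)c3)nc2n1` gives 347 nM

Compound 1 and compound 3 share a core; the change is hydrogen in place of methyl on an aromatic carbon and it gave a 2.2-fold lower number from compound 3 to compound 1 (0.34 log units; beyond the scatter). How the core of compound 2 differs from that of compound 3 is not broken down here. Compound 4 `Cc1ccc2c(O)cc(-c3cccc4ccccc34)nc2n1` arises from compound 2 by hydrogen in place of methyl on an aromatic carbon. This is the same kind of change, not the same: here the carbon is ortho to a fused ring and opposite the ring nitrogen, whereas in compound 3 to compound 1 it was next to the ring nitrogen and para to a fused ring. Given a 2.2-fold lower number from compound 3 to compound 1 (0.34 log units; beyond the scatter), a comparable modest step is expected, a 1.8-fold lower number from compound 2 to compound 4 (0.24 log units; within the scatter), though the different place makes this uncertain. Compound 4 is therefore estimated at 600 nM, likely between 250 nM and 1500 nM.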

Compound 4, concentration for 50% growth inhibition: 66.1 nM
Compound 4: middle estimate off by 9.1-fold (0.96 log units), on the high side, outside the stated range (below it).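

In this assay, putting hydrogen in place of the methyl group on the aromatic carbon of compound 2 gave a 16-fold lower number from compound 2 to compound 4 (1.20 log units; beyond the scatter) and marked the largest step seen here for this change. The change lowered the number on both cores, but its size did not carry from one to the other: the same change on two cores in this assay, a 2.2-fold lower number (0.34 log units; beyond the scatter) from compound 3 to compound 1 and a 16-fold lower number (1.20 log units; beyond the scatter) from compound 2 to compound 4, 7.2-fold (0.86 log units) apart, beyond the scatter of two such steps. The methyl group also sat in a different place in each pair, so these compounds cannot separate the effect of the core from that of the place, and two pairs make no rule for the series.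

The compounds shown leave open what an ethyl group, a methoxy group or an amine would do on that carbon. They also leave open whether the large step holds with the chlorophenyl group of compound 3.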